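Furan to thiophene on a shared hydrazone-type core

This account rests on a few compounds, and the source may have more. Where it says the series, first, only, none or still open, it means among the compounds named here.

Measured compounds:
compound 1, `N#Cc1ccc(-c2csc(N/N=C\c3cccc4ccccc34)n2)cc1`, 40%
compound 2, `C/C(=N/Nc1nc(-c2ccc(F)cc2)cs1)c1cccs1`, 40%
compound 3, `C/C(=N/Nc1nc(-c2ccc(F)cc2F)cs1)c1ccco1`, 40%

Of the compounds shown here, three have been measured in an in vitro assay on BTI-TN-5B1-4 cells for inhibition of Amine oxidase [flavin-containing] A (Homo sapiens), read by Amplex Red, with a stated time of 15 min, tested at 100 uM; on this read-out higher numbers stand for more inhibition at the one concentration tested (going by the name of the read-out) and lower numbers for less inhibition. In this assay compound 1 gives 40%, compound 2 gives 40% and compound 3 gives 40%. Compound 3 thus stands level with compounds 1 and 2 at the digits shown; its nearest neighbour is compound 1 and its furthest is compound 2, and neither gap goes beyond the scatter. Among the measured compounds shown here, no pair of these three differs in only one place, so no single step between measured compounds is available.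

Compound 4, `C/C(=N/Nc1nc(-c2ccc(F)cc2F)cs1)c1cccs1`, is not yet measured. It differs from compound 3 by thiophen-2-yl in place of furan-2-yl on a carbon with a double bond to nitrogen. Because compound 2, which carries thiophen-2-yl at this same carbon, gives 40%, level with compound 3, the step from compound 3 to compound 4 is expected to be none beyond the scatter, no change at the digits printed from compound 3 to compound 4 (within the scatter). Compound 4 is therefore estimated at 40% in this assay, with a range from 28% to 52%.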

Compound 4, a percentage reported as inhibition, at one concentration (the size of the read-out at that concentration, not a potency): 40%
Compound 4: middle estimate and measured number agree at the digits printed; the range from low to high includes it.
By their numbers in this assay, from the lowest: compounds 1, 2, 3 and 4 (each within the scatter of the next).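

In this assay, among the compounds shown here, the exchange at a carbon with a double bond to nitrogen gives no change at the digits printed from compound 3 to compound 4 (within the scatter), the first reading of thiophen-2-yl against furan-2-yl at this place with the rest of the molecule held constant. Fluoro in place of hydrogen on an aromatic carbon gives no change at the digits printed from compound 2 to compound 4 (within the scatter), so neither single exchange separates the compounds on this read-out at the one concentration tested. Nothing available here explains this outcome.

What the compounds shown leave open is whether an amine or a carboxylic acid in place of the thiophen-2-yl on this carbon would move the read-out beyond the scatter. Also open, going by these compounds, is whether these two exchanges would still show no separation in a full concentration series rather than at a single concentration.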